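Aryl in place of benzyl at the ring nitrogen

This account rests on a few compounds, and the source may have more. Where it says the series, first, only, none or still open, it means among the compounds named here.

Compound 1 `O=c1nc2oc(C3CC3)c(C#CC3CC3)c2cn1Cc1cn(Cc2ccccc2)nn1` gives the lowest number of the three in an ADME assay on WI-38 cells (Homo sapiens) for antiproliferative activity, read by MTT assay, with a stated time of 72 h (a higher number here means a weaker inhibitor, a lower number a stronger inhibitor), at 290 nM. Among the compounds with values here, compound 2 `CCCCCc1ccc(C#Cc2c(-c3ccc(CCCCC)cc3)oc3nc(=O)n(Cc4cn(-c5ccccc5F)nn4)cc23)cc1` is nearest, at 7340 nM, and compound 3 `O=c1nc2oc(C3CC3)cc2cn1Cc1cn(Cc2ccccc2)nn1` furthest, at 29700 nM; the single one-place step, a 100-fold higher number from compound 1 to compound 3 (2.01 log units; beyond the scatter), is large but concerns the aromatic carbon, not the ring nitrogen. Compound 4 `O=c1nc2oc(C3CC3)c(C#CC3CC3)c2cn1Cc1cn(-c2ccc(Cl)cc2)nn1` differs from compound 1 thus: 4-chlorophenyl in place of benzyl on an aromatic nitrogen. Within the data shown here, no measured step touches this nitrogen, and compound 2 differs from compound 1 in several places at once, so only its value is known. Without a bearing step, no change beyond the scatter is expected, so a 1.2-fold higher number from compound 1 to compound 4 (0.08 log units; within the scatter) is the estimated step. Compound 4 is therefore expected near 350 nM, between 120 nM and 1100 nM.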

Compound 4, half-maximal inhibitory concentration: 3150 nM
Compound 4: middle estimate off by 9.0-fold (0.95 log units), on the low side, outside the stated range (above it).
By their numbers in this assay, from the lowest: compound 1; then compound 4; then compound 2; then compound 3.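

The group on the aromatic nitrogen of the five-membered ring matters in this assay, with an 11-fold higher number from compound 1 to compound 4 (1.04 log units; beyond the scatter) as the first one-place step read at this position. The step is large even though benzyl and 4-chlorophenyl have the same heavy-atom count and neither has hydrogen-bond donors or acceptors. No measurement shown explains this loss.

The compounds shown do not separate the chlorine from the replacement of benzyl by an aryl group. Unsubstituted phenyl and 4-chlorobenzyl on the same nitrogen would divide the step between these two changes.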